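Swapping a hydroxy for a fluoro on a benzothiazole aniline

The source may report more compounds than this note shows. Statements on the series, on what has been measured and on what is new or still open speak of the compounds shown alone.

Measured compounds:
- compound 1, `COc1ccc(C(=O)/C=C\Nc2ccc(-c3nc4cc(OC)c(OC)c(OC)c4s3)cc2C)cc1O`, 15400 nM
- compound 2, `COc1ccc2nc(-c3ccc(N/C=C\C(=O)c4ccc(OC)c(O)c4)c(C)c3)sc2c1`, 18000 nM
- compound 3, `COc1ccc(C(=O)/C=C\Nc2ccc(-c3nc4cc(OC)c(OC)c(OC)c4s3)cc2C)cc1F`, 1690 nM

These three compounds were tested in a functional assay on A549 cells (Homo sapiens) for antiproliferative activity, read by sulforhodamine B assay, with a stated time of 48 h; a lower number here means a stronger inhibitor, a higher number a weaker inhibitor. Compound 1 gives 15400 nM and compound 2 gives 18000 nM, two numbers that sit within the usual scatter of each other. Within the data shown here, the change fluoro in place of hydroxy on an aromatic carbon is the only way in which compound 3 differs from compound 1. In this assay compound 3 gives 1690 nM, and the step of a 9.1-fold lower number from compound 1 to compound 3 (0.96 log units; beyond the scatter) shows a clear gain.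

Compound 4, `COc1ccc2nc(-c3ccc(N/C=C\C(=O)c4ccc(OC)c(F)c4)c(C)c3)sc2c1`, has not yet been measured. It relates to compound 2 exactly as compound 3 relates to compound 1: the change is fluoro in place of hydroxy on an aromatic carbon, and the surroundings of the changed atom are described in the same words in both pairs, so this is the same change made on a second core. How the core of compound 2 differs from that of compound 1 is not broken down here.

The expectation for compound 4 in this assay rests on one example. Because compound 3 improved on compound 1 by a 9.1-fold lower number from compound 1 to compound 3 (0.96 log units; beyond the scatter), a step of similar direction and size is expected here, with some allowance for the core being different: the expected step is a 7.2-fold lower number from compound 2 to compound 4 (0.86 log units; beyond the scatter). Compound 4 is therefore estimated at 2500 nM, with a likely range from 900 nM to 8000 nM.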

Compound 4, half-maximal inhibitory concentration: 1400 nM
Compound 4: middle estimate off by 1.8-fold (0.25 log units), on the high side; the measured number falls inside the stated range.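

In this assay, fluoro in place of hydroxy lowers the number on the second core as well, giving a 13-fold lower number from compound 2 to compound 4 (1.11 log units; beyond the scatter) on the 3-hydroxy-4-methoxyphenyl to 3-fluoro-4-methoxyphenyl change. Set beside the first example, the two steps point the same way and do not differ by more than measurement noise would allow, so in these two pairs the gain carried over from one core to the other in both direction and size: the same change on two cores in this assay, a 9.1-fold lower number (0.96 log units; beyond the scatter) from compound 1 to compound 3 and a 13-fold lower number (1.11 log units; beyond the scatter) from compound 2 to compound 4, 1.4-fold (0.15 log units) apart, within the scatter of two such steps

Among these compounds, this is still only two pairs in a single cell-based test, so it does not establish that the change would behave the same way on a third core, and it does not explain why replacing hydroxy with fluoro gives a lower number in these cells. The numbers record the effect on cell growth and nothing about the route by which that effect arises. As far as these compounds go, what remains open is how a chloro group, an amine or a nitrile at the same place on the ring would compare with fluoro. Also open, from the compounds shown here alone, is whether the gain would persist if the neighbouring methoxy group were replaced by a longer chain such as ethoxy.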